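The compounds below may be only part of what the source reports. "The series", "measured", "known", "first", "only" and "open" are said of these compounds alone.

Measured so far:
compound 1, `OC[C@H]1O[C@@H](OCCc2ccc(O)c(Br)c2)[C@H](O)[C@@H](O)[C@@H]1O`: > 100000 nM
compound 2, `OC[C@H]1O[C@@H](OCCc2cc(O)c(O)c(O)c2)[C@H](O)[C@@H](O)[C@@H]1O`: 38100 nM

In a functional assay, with a stated time of 30 min (on this read-out higher numbers stand for weaker inhibition and lower numbers for stronger inhibition), compound 1 gives a limit only, > 100000 nM; this is the limit of > 100000 nM in this assay, at which 1 of the 2 values shown sits. For the measured compounds named here, compound 2 is the one compound of the pair with a number in this assay, giving 38100 nM, so compound 2 stands as the sole reference point for the series. Going by the values given here, no step between two measured compounds with a single point of difference is available.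

Compound 3, `OC[C@H]1O[C@@H](OCCc2cc(O)c(O)c(O)c2)[C@H](O)[C@@H](O)[C@H]1O`, is not yet measured in this assay. Its relation to compound 2: the two compounds have the same atoms and bonds and differ only in configuration as drawn: 1 of 5 stereo elements differ; a stereocentre at a saturated ring carbon is drawn S in compound 2 and R in compound 3. With the atoms and bonds unchanged and one stereocentre at a saturated ring carbon inverted, the step from compound 2 to compound 3 is expected to stay within the scatter, leaning if anything toward weaker inhibition: a 1.3-fold higher number from compound 2 to compound 3 (0.12 log units; within the scatter). Compound 3 is therefore estimated at 50000 nM, with a range from 15000 nM to 150000 nM.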

Compound 3, half-maximal inhibitory concentration: 35900 nM
The estimate for compound 3 lay 1.4-fold (0.14 log units) above the measured number; the range from low to high includes it.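

In this assay, inverting one stereocentre at a saturated ring carbon gives a 1.1-fold lower number from compound 2 to compound 3 (0.03 log units; within the scatter), a step within the scatter. For the compounds shown here, this is the first comparison with a single point of difference, and it shows no measurable preference for either drawn configuration at this position, S or R, at this level of inhibition. The reading concerns configuration alone, because no atom or bond separates the pair: the fact that compounds 2 and 3 differ only in the configuration as drawn

From the compounds shown here alone, whether an amine or a carboxylic acid on the shared core would show the same indifference to configuration stays open, as does the effect of inverting any other stereocentre. Compound 1 gives only a limit, > 100000 nM, and offers no single-place comparison with the other compounds.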